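Methoxy-to-hydroxy step on a urea pyrazole series

The source may report more compounds than this note shows. Statements on the series, on what has been measured and on what is new or still open speak of the compounds shown alone.

Measured in a functional assay on SK-OV-3 cells (Homo sapiens) for inhibition, read by sulforhodamine B assay, with a stated time of 48 h; on this read-out higher numbers stand for weaker inhibition of growth and lower numbers for stronger inhibition of growth:
- compound 1 `COc1cc(-c2nn(-c3cccc(NC(=O)Nc4cc(C(F)(F)F)cc(C(F)(F)F)c4)c3)cc2-c2ccncc2)ccc1Cl`: 1090 nM
- compound 2 `O=C(Nc1cccc(-n2cc(-c3ccncc3)c(-c3ccc(Cl)c(O)c3)n2)c1)Nc1cc(C(F)(F)F)cc(C(F)(F)F)c1`: 1350 nM
- compound 3 `COc1cc(-c2nn(-c3cccc(NC(=O)Nc4ccc(Cl)c(C(F)(F)F)c4)c3)cc2-c2ccncc2)ccc1Cl`: 1450 nM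

Compound 1 and compound 2 differ by one change, (hydrogen in place of methyl on an oxygen on an aromatic ring), and the step of a 1.2-fold higher number from compound 1 to compound 2 (0.09 log units; within the scatter). Compound 3 carries a different urea partner; the difference between the cores of compound 1 and compound 3 is not broken down here. Compound 4 `O=C(Nc1cccc(-n2cc(-c3ccncc3)c(-c3ccc(Cl)c(O)c3)n2)c1)Nc1ccc(Cl)c(C(F)(F)F)c1` is not yet measured and differs from compound 3 by hydrogen in place of methyl on an oxygen on an aromatic ring, the same change as from compound 1 to compound 2, at the same place. Among the measured compounds shown here, the step from compound 3 to compound 4 is expected to be about a 1.2-fold higher number from compound 3 to compound 4 (0.07 log units; within the scatter), resting on the single earlier step of a 1.2-fold higher number from compound 1 to compound 2 (0.09 log units; within the scatter). Compound 4 is therefore estimated at 1700 nM in this assay, between 900 nM and 3500 nM.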

Compound 4, concentration for 50% growth inhibition: 1340 nM
For compound 4 the middle estimate is 1.3-fold (0.10 log units) above the measured one; the measured number falls inside the stated range.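

In this assay, methoxy to hydroxy on the 4-chloro-3-methoxyphenyl group gives a 1.1-fold lower number from compound 3 to compound 4 (0.03 log units; within the scatter), so no step beyond the scatter appears on this second core. Across the two urea partners the change reads the same within the scatter: the same change on two cores in this assay, a 1.2-fold higher number (0.09 log units; within the scatter) from compound 1 to compound 2 and a 1.1-fold lower number (0.03 log units; within the scatter) from compound 3 to compound 4, 1.3-fold (0.13 log units) apart, within the scatter of two such steps. This supports carrying the change between these two cores without expecting a shift in this read-out, but two pairs do not show that it would hold on other cores, or that either group matters on these.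

From the compounds shown here alone, it remains open whether an amine or a carboxylic acid in place of the hydroxy, or a longer chain on the oxygen, would stay in the same range. Urea partners beyond these two also remain open.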